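A few compounds are considered here, and "the series" means these few. Any claim that something is new, unique, unknown or untested is made for them only; others in the source may bear on it.

Compound 1, `CC(=O)OC(C)n1cnc2c(Cl)nc(N)nc21`. In a functional assay on WI-38 cells (Homo sapiens) for inhibition (a lower number here means a stronger inhibitor, a higher number a weaker inhibitor), compound 1 gives > 500000 nM, which is a limit of the assay and not a number.
Compound 2, `CC(=O)OCCOn1cnc2c(Cl)nc(N)nc21`. In this assay compound 2 gives > 500000 nM, also a limit of the assay.
Compound 3, `CC(=O)OC(C)n1cnc2c(Cl)nc(I)nc21`. In this assay compound 3 gives 14100 nM.

From compound 1 to compound 3 the change is iodo in place of amino on an aromatic carbon, and it brought an at least 35-fold lower number from compound 1 to compound 3 (1.54 log units; beyond the scatter). The exact size of that step is open because of the limit of > 500000 nM in this assay, at which 2 of the 3 values shown sit.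

Compound 4, `CC(=O)OCCOn1cnc2c(Cl)nc(I)nc21`, has not yet been measured. It differs from compound 2 by iodo in place of amino on an aromatic carbon, the same change as from compound 1 to compound 3. How the core of compound 2 differs from the core of compound 1 is not broken down here.

For the measured compounds named here, for compound 4 a step of an at least 25-fold lower number from compound 2 to compound 4 (1.39 log units; beyond the scatter) is expected, beside the earlier at least 35-fold lower number from compound 1 to compound 3 (1.54 log units; beyond the scatter), resting on the single measured pair. Compound 4 is therefore estimated at 20000 nM in this assay, with a plausible range from 5000 nM to 150000 nM.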

Compound 4, half-maximal inhibitory concentration: 63100 nM
The estimate for compound 4 lay 3.2-fold (0.50 log units) below the measured number; low and high end bracket the measured number.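

In this assay, iodo in place of amino on an aromatic carbon also lowers the number on the second core, bringing an at least 7.9-fold lower number from compound 2 to compound 4 (0.89 log units; beyond the scatter). The change therefore points the same way on both cores shown, but how far it goes on each is not settled: the same change on two cores in this assay, an at least 35-fold lower number (1.54 log units; beyond the scatter) from compound 1 to compound 3 and an at least 7.9-fold lower number (0.89 log units; beyond the scatter) from compound 2 to compound 4; the limit leaves it open whether they differ
Compound 2 gives > 500000 nM, which is a limit of the assay and not a number, so the true size of its step remains unknown, and the same holds for the step from compound 1: the limit of > 500000 nM in this assay, at which 2 of the 4 values shown sit.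

The compounds shown leave open whether another group at the carbon between two ring nitrogen atoms, such as bromo or a simple amine carrying a methyl group, would lower the number as iodo does. They also leave open whether the change would carry over to a core with a carboxylic acid in place of the acetate ester, or with a longer chain on the ring nitrogen.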